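Swapping a trifluoromethyl for a triazole on the amide carbonyl

The compounds below may be only part of what the source reports. "The series", "measured", "known", "first", "only" and "open" are said of these compounds alone.

Measured so far:
compound 1 `O=C(C1CCN(C(=O)C(F)(F)F)CC1)N1N=CCC1c1ccccc1`: 4.9
compound 2 `CC(C)(C)C(=O)N1N=CCC1c1c[nH]cn1`: 1.7
compound 3 `CC(C)(C)C(=O)N1N=CCC1C1CCCC1`: 6.7

In a physicochemical assay for lipophilicity, read by HPLC, measured as chromatographic lipophilicity, at pH 7.4 (a higher number here means a more lipophilic compound, a lower number a more polar compound), compound 1 stands second highest of the three; compound 3 sits higher and compound 2 sits lower. Compound 4 `O=C(c1c[nH]nn1)N1CCC(C(=O)N2N=CCC2c2ccccc2)CC1` differs from compound 1 in one place: 1H-1,2,3-triazol-4-yl in place of trifluoromethyl on a carbonyl carbon. Among the compounds with values here, the only measured step runs the opposite way, where a carbon-only ring entered in place of an aromatic ring holding hetero atoms: a number 5.00 log units higher from compound 2 to compound 3 (beyond the scatter). The change into compound 4 brings such a ring in, so a clear drop in this assay is expected, though smaller than that step, as the group entering is also smaller. Compound 4 is estimated at 3 (range 2 to 4), an expected step of a number 1.90 log units lower from compound 1 to compound 4 (beyond the scatter).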

Compound 4, distribution coefficient: 2
Compound 4: the middle estimate sits 1.00 log units above what was measured; low and high end bracket the measured number.
By their numbers in this assay, from the lowest: compounds 2 and 4 (each within the scatter of the next); then compound 1; then compound 3.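

In this assay the swap gives a number 2.90 log units lower from compound 1 to compound 4 (beyond the scatter) on a carbonyl carbon whose other neighbour is an amide-type nitrogen in a ring, so the number here responds strongly to the group at this place. The earlier step lay on a saturated ring carbon and could say nothing about this place. No other measurement bears on why the number falls.

From the compounds shown here alone, with one swap at this place, it remains open whether the drop follows the incoming ring, its nitrogens or the departure of trifluoromethyl. A methyl group, a dimethylamino group or a carboxylic acid on the same carbonyl carbon would help separate these.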